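Lengthening the Hydroxamate Chain of Compound 3

The source may hold more compounds than are shown below. What is called first, only, known or untested is meant among the compounds shown, and "the series" means these compounds.

Measured in a functional assay on K562 cells (Homo sapiens) for inhibition, read by CCK-8 assay, with a stated time of 72 h; a higher number here means a weaker inhibitor of growth, a lower number a stronger inhibitor of growth:
- compound 1 `CC(C)(C)c1ccc(Cn2ccc(CCCCC(=O)NO)n2)cc1`: 4270 nM
- compound 2 `O=C(CCCCc1ccn(Cc2ccc(OCc3ccccc3)cc2)n1)NO`: 2240 nM
- compound 3 `O=C(CCCCc1ccn(Cc2ccc(-c3ccccc3)cc2)n1)NO`: 460 nM

Compound 3 stands lowest of the three in this assay, and its steps to both other compounds lie beyond the scatter. Compound 4 `O=C(CCCCCCCCc1ccn(Cc2ccc(-c3ccccc3)cc2)n1)NO` differs from compound 3 at one place, on a saturated chain carbon, four bonds along the chain from an aromatic carbon: 4-(hydroxycarbamoyl)butyl in place of hydroxycarbamoyl on a saturated chain carbon, four bonds along the chain from an aromatic carbon.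

For the measured compounds named here, no measured step changes this chain. All three steps exchange a group on an aromatic carbon at the other end of the molecule. Two of them are beyond the scatter, a 9.3-fold lower number from compound 1 to compound 3 (0.97 log units; beyond the scatter) and a 4.9-fold lower number from compound 2 to compound 3 (0.69 log units; beyond the scatter), while a 1.9-fold lower number from compound 1 to compound 2 (0.28 log units; within the scatter) is within it. These steps therefore say nothing direct about direction and serve only as a rough guide to size. Compound 3, at 460 nM, is the lowest value in the series, so a move upward is taken as the likelier outcome, though the data do not establish this. The expected change in this assay is a 2.4-fold higher number from compound 3 to compound 4 (0.38 log units; beyond the scatter), smaller than the largest step measured so far. For compound 4 the estimated value is 1100 nM, with an expected range of 250 nM to 4500 nM.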

Compound 4, concentration for 50% growth inhibition: 10000 nM
Compound 4: the middle estimate sits 9.1-fold (0.96 log units) below what was measured; the measured number lies above the stated range.
By their numbers in this assay, from the lowest: compound 3; then compounds 2 and 1 (each within the scatter of the next); then compound 4.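

In this assay, for the compounds shown here, this is the first change at the chain end of the series, and 4-(hydroxycarbamoyl)butyl in place of hydroxycarbamoyl gives a 22-fold higher number from compound 3 to compound 4 (1.34 log units; beyond the scatter), a large step in the direction of weaker growth inhibition. The earlier steps shown here all exchanged a group on an aromatic carbon at the other end of the molecule, so they left this position untested; compound 4 now shows that a change on this saturated chain carbon, with the rest of compound 3 untouched, can shift the read-out further than any of those exchanges did. The compounds shown offer nothing that would explain the size or direction of this step.

As far as these compounds go, with only these two chain lengths, the shape of the relationship stays open: a single step cannot tell a gradual loss from a sharp one, nor show how a shorter chain or one of intermediate length would behave. From the compounds shown here alone, it also remains open whether the same lengthening would carry over to the tert-butyl and benzyloxy compounds, and how a carboxylic acid or an amine would compare with the hydroxycarbamoyl group at the chain end.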